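The source may report more compounds than this note shows. Statements on the series, on what has been measured and on what is new or still open speak of the compounds shown alone.

Compound 1, `Cc1cccc(S(=O)(=O)c2ccc(CNC(=O)c3cc4cnccc4[nH]3)cc2)c1`: 49%
Compound 2, `O=C(NCc1ccc(S(=O)(=O)c2ccc(F)c(F)c2)cc1)c1cc2cnccc2[nH]1`: 100%
Compound 3, `O=C(NCc1ccc(S(=O)(=O)N2CCCCC2)cc1)c1cc2ccncc2[nH]1`: 50%

All three were measured in an ADME assay on microsomes from liver (Homo sapiens) for metabolic stability, read by LC-MS, with a stated time of 30 min, tested at 1 uM; on this read-out higher numbers stand for a more stable compound and lower numbers for a less stable compound. Compound 2 stands highest of the three: the nearest is compound 3 with 50%, the furthest is compound 1 with 49%, and both gaps lie beyond the scatter.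

The next compound, compound 4, `O=C(NCc1ccc(S(=O)(=O)c2ccc(F)cc2)cc1)c1cc2cnccc2[nH]1`, differs from compound 2 in a single place: hydrogen in place of fluoro on an aromatic carbon. One of the two fluoro groups on the ring attached to the sulfonyl sulfur is removed, leaving a 4-fluorophenyl group.

Among the measured compounds shown here, only one measured step touches this part of the molecule: a number 51 percentage points higher from compound 1 to compound 2 (beyond the scatter). That step exchanged a whole 3-methylphenyl group for a 3,4-difluorophenyl group and brought a large rise in this assay. Compound 4 keeps the fluorophenyl pattern but gives up one fluoro, so it holds part of what compound 2 gained in that step. For the measured compounds named here, there is no measured step that isolates a single fluoro, so the size of the loss is uncertain. A moderate drop is expected in this assay, a number 20 percentage points lower from compound 2 to compound 4 (beyond the scatter), since compound 2 already sits at the top of the range and a single fluoro removal is a smaller change than the step from compound 1 to compound 2.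

Compound 4 is estimated at 80%, in the range 55% to 100%.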

Compound 4, percent of the compound remaining: 91%
For compound 4 the middle estimate is 11 percentage points below the measured one; low and high end bracket the measured number.
By their numbers in this assay, from the lowest: compounds 1 and 3 (each within the scatter of the next); then compounds 4 and 2 (each within the scatter of the next).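

In this assay, taking one fluoro off the ring on the sulfonyl sulfur gives a number 9 percentage points lower from compound 2 to compound 4 (within the scatter), so this read-out does not tell the 4-fluorophenyl group apart from the 3,4-difluorophenyl group. The second fluoro, the one removed here, therefore shows no effect that can be separated from ordinary variation between repeated measurements, and the large gain over the 3-methylphenyl group does not depend on having both fluoro groups: the single-fluoro ring gives a number 42 percentage points higher from compound 1 to compound 4 (beyond the scatter), a step of similar size to a number 51 percentage points higher from compound 1 to compound 2 (beyond the scatter). Nothing measured here explains why these rings behave as they do in this assay.

The compounds shown leave open whether the gain comes from having a fluoro on the ring or simply from losing the methyl group, and a plain phenyl ring on the sulfonyl sulfur would separate these two readings. On these data alone, it also remains open whether other groups in the place of that fluoro, such as a chloro or a methoxy group, would keep the number close to those of compound 2 and compound 4 or bring it down towards that of compound 1.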